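The source may hold more compounds than are shown below. What is called first, only, known or untested is meant among the compounds shown, and "the series" means these compounds.

Compound 2 `CCOc1c(-c2occ(C)c2CO)ccc2c(CC)cccc12` stands in a functional assay on A549 cells (Homo sapiens) for cytotoxicity, read by MTT assay, with a stated time of 72 h (a higher number here means that more compound is needed for the effect, a lower number that less compound is needed), at a limit of the assay: its value there is > 10 ug/mL. Compound 1 `CCOc1c(-c2occ(C)c2C(=O)O)ccc2c(CC)cccc12` likewise gives only a limit in this assay, > 10 ug/mL. The step that the two limits leave unreadable from compound 1 to compound 2 cannot be read in size, since both values sit at the limit of > 10 ug/mL in this assay, at which 2 of the 2 values shown sit. Compound 3 `CCOc1c(-c2occ(C)c2COC)ccc2c(CC)cccc12` has not yet been measured in this assay; it differs from compound 2 by methyl in place of hydrogen on an oxygen on a saturated carbon. No measured step bears directly on this change, and the one step shown, from the carboxy compound to the hydroxymethyl compound, yields no size. The step that the limit leaves unreadable from compound 2 to compound 3 is thus expected to be none beyond the scatter, and the reading for compound 3 is expected most likely to remain a limit. For compound 3 the estimate in this assay is 15 ug/mL, with a range from 8 ug/mL to 40 ug/mL.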

Compound 3, concentration for half-maximal effect: > 10 ug/mL
Compound 3 ended at the assay's limit (the forecaster's own chance of this, stated with the estimate: 80%); the middle value is on the limit's open side.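

No step can be read among compound 1, compound 2 and compound 3 in this assay, since each gives only a limit: the limit of > 10 ug/mL in this assay, at which 3 of the 3 values shown sit. The compounds shown leave open how far each lies beyond that limit, and whether the carboxy, hydroxymethyl and methoxymethyl compounds differ at all.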